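Methyl to trifluoromethyl on the aromatic ring

The source may hold more compounds than are shown below. What is called first, only, known or untested is meant among the compounds shown, and "the series" means these compounds.

In a functional assay on KB cells (Homo sapiens) for inhibition (on this read-out higher numbers stand for weaker inhibition and lower numbers for stronger inhibition), compound 1 `Nc1nc2cc(Cl)c(Cl)cc2n1Cc1ccccc1` gives 170000 nM. Compound 2 `Nc1nc2cc(Cl)c(Cl)cc2n1Cc1cccc(Cl)c1` gives 65000 nM and compound 3 `Cc1cccc(Cn2c(N)nc3cc(Cl)c(Cl)cc32)c1` gives 65000 nM, so compound 3 stands level with compound 2 at the low end of the three numbers. Compound 4 `Nc1nc2cc(Cl)c(Cl)cc2n1Cc1cccc(C(F)(F)F)c1` has trifluoromethyl in place of methyl on an aromatic carbon, meta to a large group: trifluoromethyl in place of methyl on an aromatic carbon. Two modest steps bear on this, a 2.6-fold lower number from compound 1 to compound 2 (0.42 log units; beyond the scatter) and a 2.6-fold lower number from compound 1 to compound 3 (0.42 log units; beyond the scatter). Going by the values given here, the closest precedent is no change at the digits printed from compound 2 to compound 3 (within the scatter), so exchanging one of these groups for another has not yet moved the number. Among the compounds with values here, no trifluoromethyl compound has been measured. The expected change is none beyond the scatter, estimated as a 1.2-fold lower number from compound 3 to compound 4 (0.07 log units; within the scatter). For compound 4 the estimate is 55000 nM, with an expected range of 22000 nM to 130000 nM.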

Compound 4, half-maximal inhibitory concentration: 45000 nM
Compound 4: the middle estimate sits 1.2-fold (0.09 log units) above what was measured; the measured number falls inside the stated range.
By their numbers in this assay, from the lowest: compounds 4, 2 and 3 (each within the scatter of the next); then compound 1.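

In this assay trifluoromethyl on this aromatic carbon does not separate from the earlier groups, with a 1.4-fold lower number from compound 3 to compound 4 (0.16 log units; within the scatter) and a 1.4-fold lower number from compound 2 to compound 4 (0.16 log units; within the scatter) as its steps from methyl and chloro. Against hydrogen, a 3.8-fold lower number from compound 1 to compound 4 (0.58 log units; beyond the scatter) is the third step beyond the scatter, so chloro, methyl and trifluoromethyl all stand apart from hydrogen but not from one another. Nothing available on these compounds accounts for this.

Going by these compounds, whether an amine, a carboxylic acid or a longer chain on this carbon would stay level with these three groups remains open.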